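Replacing the Furan Arm: From Compound 1 to Compound 4

This account rests on a few compounds, and the source may have more. Where it says the series, first, only, none or still open, it means among the compounds named here.

Compound 1 `c1ccc(CCc2ccc3c(NCCCNCc4ccco4)ccnc3c2)cc1` was measured in a physicochemical assay for solubility, with a stated time of 18 h, at pH 7.4 (a lower number here means a less soluble compound, a higher number a more soluble compound), where compound 1 gives 4200 nM. Compound 2 `c1ccc(Cc2ccc3c(NCCCNCc4ccco4)ccnc3c2)cc1` gives 4200 nM in this assay, and compound 3 `Clc1ccc(Oc2ccc3c(NCCCNCc4ccco4)ccnc3c2)cc1` gives 14500 nM. Of these three numbers compound 1 stands level with compound 2 at the digits shown, the two together the lowest, with compound 3 furthest away. The known steps are no change at the digits printed from compound 1 to compound 2 (within the scatter) and a 3.5-fold higher number from compound 1 to compound 3 (0.54 log units; beyond the scatter), together with a 3.5-fold higher number from compound 2 to compound 3 (0.54 log units; beyond the scatter); all three alter the group on the aromatic carbon of the shared core. Compound 4 `COc1ccc(F)cc1CNCCCNc1ccnc2cc(CCc3ccccc3)ccc12` differs from compound 1 at the other end: 5-fluoro-2-methoxyphenyl in place of furan-2-yl on a saturated chain carbon bound to an amine nitrogen. Within the data shown here, no measured step touches this position, so nothing here fixes the size or direction of the change; the only guide is that exchanging one aromatic group for another in no change at the digits printed from compound 1 to compound 2 (within the scatter) left the number unmoved. Compound 4 is therefore expected to stay near compound 1, the step of a 1.4-fold lower number from compound 1 to compound 4 (0.15 log units; within the scatter) not clearly beyond the scatter. Compound 4 is estimated at 3000 nM, within a range from 800 nM to 9000 nM.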

Compound 4, solubility: 4200 nM
Compound 4: the middle estimate sits 1.4-fold (0.15 log units) below what was measured; the range from low to high includes it.
By their numbers in this assay, from the lowest: compounds 1, 2 and 4 (each within the scatter of the next); then compound 3.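

In this assay the arm on a saturated chain carbon bound to an amine nitrogen now has a measured step of its own: the exchange of furan-2-yl for 5-fluoro-2-methoxyphenyl gives no change at the digits printed from compound 1 to compound 4 (within the scatter) even though a five-membered aromatic ring with 1 hetero atom gives way to a six-membered aromatic ring of carbon only, and 5 heavy atoms to 9. The earlier steps shown here all altered the group on the aromatic carbon of the shared core, so they showed nothing about this position. No measurement is available that would account for this result.

As far as these compounds go, whether an amine or a carboxylic acid in place of the aromatic ring would also leave the number in place remains open. So does whether the same exchange would behave alike on compound 3, which carries 4-chlorophenoxy.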